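Moving the Carboxylate on a Glutamate Receptor Modulator Series

This account rests on a few compounds, and the source may have more. Where it says the series, first, only, none or still open, it means among the compounds named here.

Compound 1 `Cc1c(OCCCCOc2ccc(C(=O)O)cc2Cl)ccc(C(=O)CC2CCCC2)c1O`: 82.2%
Compound 2 `Cc1c(OCCCCOc2ccc(C(=O)O)cc2)ccc(C(=O)CC(C)C)c1C`: 19%

In an assay on HEK293 cells for positive allosteric modulation of metabotropic glutamate receptor 2 (Rattus norvegicus), read by thallium flux, with a stated time of 2.5 min (on this read-out lower numbers stand for smaller maximal responses and higher numbers for larger maximal responses), compound 1 gives 82.2%, the higher of the two numbers recorded, and compound 2 gives 19%, a gap that lies beyond the scatter. Compound 3 `Cc1ccc(C(=O)O)cc1OCCCCOc1ccc(C(=O)CC2CCCC2)c(O)c1C` is not yet measured. It differs from compound 1 in one place: 5-carboxy-2-methylphenyl in place of 4-carboxy-2-chlorophenyl on an oxygen on a saturated carbon. Going by the values given here, no single-change step has been measured, so the size of the expected step rests on the change itself. The step of a number 27.2 percentage points lower from compound 1 to compound 3 (beyond the scatter) is expected to be downward and beyond the scatter. Compound 3 is estimated at 55%, within 25% to 85%.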

Compound 3, largest response reached (reported as percent of maximum), in percent of the reference or control that the assay uses: 67.5%
Compound 3: the middle estimate sits 12.5 percentage points below what was measured; measured number inside the range.
By their numbers in this assay, from the lowest: compound 2; then compound 3; then compound 1.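

At this place, on an oxygen on a saturated carbon, 5-carboxy-2-methylphenyl in place of 4-carboxy-2-chlorophenyl gives in this assay a first single-change step, a number 14.7 percentage points lower from compound 1 to compound 3 (beyond the scatter), so this aryl group can be altered with only a modest loss of maximal response. The change alters two things at once, the placing of the carboxy group and chlorine against methyl, and the compounds shown do not separate them. Nothing measured here explains the step.

Which of the two alterations carries the step remains open, as does how an amide or a tetrazole would fare in place of the carboxylic acid at this place.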